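The source may hold more compounds than are shown below. What is called first, only, known or untested is meant among the compounds shown, and "the series" means these compounds.

Measured in a functional assay on the whole organism (strain Sprague-Dawley) for inhibition, with Rattus norvegicus as the target, with a stated time of 10 min; a lower number here means that less compound is needed, a higher number that more compound is needed for the effect:
- Compound 1 `O=C(O)c1cnc(-c2ccccc2F)[nH]c1=O`: 5 mg/kg
- Compound 2 `COc1ccc(OC)c(-c2ncc(C(=O)O)c(=O)[nH]2)c1`: 1 mg/kg
- Compound 3 `CCOC(=O)c1cnc(-c2ccccc2F)[nH]c1=O`: > 10 mg/kg

The entry for compound 3 is a limit of the assay and not a number, so its true position on the scale is open. Compound 4 `CCOC(=O)c1cnc(-c2ccccc2OC(C)C)[nH]c1=O` keeps the ethyl group of compound 3 but has isopropoxy in place of fluoro on an aromatic carbon.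

For the measured compounds named here, the only measured step is an at least 2.0-fold higher number from compound 1 to compound 3 (0.30 log units; that floor lies within the scatter). It concerns the ethyl group, not the aromatic ring, so it says little about this change. The nearest hint comes from compound 2, which carries methoxy groups on its aromatic ring rather than fluoro and gives 1 mg/kg, a lower number than compound 1 at 5 mg/kg. On that hint alone, a move toward a lower number is expected, as an at least 3.3-fold lower number from compound 3 to compound 4 (0.52 log units; beyond the scatter). For compound 4 the expected value is 3 mg/kg, with an estimated range of 0.5 mg/kg to 15 mg/kg.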

Compound 4, dose for 50% inhibition: 2 mg/kg
Estimate against measurement, compound 4: 1.5-fold (0.18 log units) above; low and high end bracket the measured number.
By their numbers in this assay, from the lowest: compounds 2 and 4 (each within the scatter of the next); then compound 1. At a limit, above all of these: compound 3.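

For the compounds shown here, with the ethyl group held fixed, the swap to isopropoxy on an aromatic carbon ortho to a large group gives the first direct reading of a change at this place in this assay, and the result is an at least 5.0-fold lower number from compound 3 to compound 4 (0.69 log units; beyond the scatter), a step beyond the scatter. Compound 4 also shows that the ethyl group does not by itself hold a compound at the limit of this assay. Compound 3 stands at a limit and not at a number, so this step is only a floor, and its true size stays open: the limit of > 10 mg/kg in this assay, at which 1 of the 4 values shown sits.

The compounds shown leave open whether ethoxy, a longer chain such as butoxy, or an amine at this place would give a similar number. They also do not show why isopropoxy differs from fluoro here, or whether the same swap would move the number for compound 1, which has hydrogen in place of the ethyl group.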